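Chloro in Place of Methyl on Compound 1

The source may hold more compounds than are shown below. What is called first, only, known or untested is meant among the compounds shown, and "the series" means these compounds.

Within the data shown here, compound 1 `Cc1ccc(C2CNN=C2S(=O)(=O)CC2=NCCS2)cc1` is one of two compounds measured in a functional assay, tested at 100 ug/mL; a higher number here means a stronger effect of the compound at the concentration tested, a lower number a weaker effect. In this assay compound 1 gives 45.1%, and compound 2 `Cc1ccc(C2CNN=C2S(=O)(=O)CC2=NCCO2)cc1` gives 46.8%; the two numbers sit together, since the step of a number 1.7 percentage points higher from compound 1 to compound 2 (within the scatter) lies within the scatter. Compound 3 `O=S(=O)(CC1=NCCS1)C1=NNCC1c1ccc(Cl)cc1` differs from compound 1 in another place: chloro in place of methyl on an aromatic carbon. Among the measured compounds shown here, the only measured step, from compound 1 to compound 2, concerns a group on a saturated chain carbon bound to a sulfonyl sulfur, not the aromatic ring, so no measured step bears on the change toward compound 3. With nothing that speaks for a shift in either direction, compound 3 is expected to show no step beyond the scatter, a number 0.1 percentage points lower from compound 1 to compound 3 (within the scatter). In this assay compound 3 is therefore estimated at 45%, with a range from 28% to 62%.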

Compound 3, a percentage reported as activity, at one concentration (the size of the read-out at that concentration, not a potency): "not active" (no number reported)
The entry for compound 3 holds no number; there is nothing to compare the estimate with.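

In this assay, among these compounds, compound 3 is entered as "not active" (no number reported), so no step from compound 1 to compound 3 can be read. Nothing shown accounts for this entry. The compounds shown leave open how large any effect of chloro in place of methyl is.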